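The compounds below may be only part of what the source reports. "The series", "measured", "known", "first", "only" and "open" are said of these compounds alone.

Compound 1 `O=C1c2ccc(OCc3cccc(-c4ccc(Cl)cc4F)c3)cc2CN1C1CCCC1` has no number in an ADME assay on microsomes from liver (Rattus norvegicus) for metabolic stability, read by LC-MS, with a stated time of 1 h, at 37 degrees C, tested at 4 uM; on this read-out lower numbers stand for a less stable compound and higher numbers for a more stable compound: in this assay compound 1 gives "not determined" (no result reported), so it cannot be placed on the scale. Among the measured compounds shown here, the only measured point is compound 2 `O=C(O)c1cc(-c2cccc(COc3ccc4c(=O)n(C5CCC5)sc4c3)c2)ccc1Cl`, which carries a carboxylic acid on a different core; in this assay compound 2 gives 67%, and no step between it and compound 1 is known. Compound 3 `O=C(O)c1ccc(-c2cccc(COc3ccc4c(c3)CN(C3CCCC3)C4=O)c2)c(Cl)c1` keeps the core of compound 1 and differs from it by 4-carboxy-2-chlorophenyl in place of 4-chloro-2-fluorophenyl on an aromatic carbon, the 4-carboxy-2-chlorophenyl entering on an aromatic carbon meta to a large group. For the measured compounds named here, with no value for compound 1, no step in this assay from compound 1 to compound 3 can be sized or given a direction; only an estimate for compound 3 on its own is possible. Compound 3 is expected to give about 65% in this assay, in a range from 40% to 90%.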

Compound 3, percent of the compound remaining: 3%
For compound 3 the middle estimate is 62 percentage points above the measured one; the whole stated range lies above it.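

In this assay no step can be read from compound 1 to compound 3, as compound 1 carries no number on this scale. The compounds shown leave open what 4-carboxy-2-chlorophenyl in place of 4-chloro-2-fluorophenyl does on the shared core. Nothing shown here bears on the low value of compound 3.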